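A few compounds are considered here, and "the series" means these few. Any claim that something is new, unique, unknown or untested is made for them only; others in the source may bear on it.

In a functional assay on HCT-116 cells (Homo sapiens) for antiproliferative activity, read by MTT assay, with a stated time of 24 h (a lower number here means a stronger inhibitor, a higher number a weaker inhibitor), compound 1 `COc1cccc(C(=O)Oc2ccc3c(=O)c(-c4cc(OC)c(OC)cc4OC)coc3c2)c1` gives > 10000 nM, which is a limit of the assay and not a number. Among the measured compounds shown here, compound 2 `COc1cc(OC)c(-c2coc3cc(OCc4ccc(Cl)cc4)ccc3c2=O)cc1OC` gives 4450 nM, so it holds the only true number so far, and nothing yet shows how far that number can move. The next structure, compound 3 `COc1cc(OC)c(-c2coc3cc(OCc4cccc(Br)c4)ccc3c2=O)cc1OC`, keeps the shared core and changes only the outer group: 3-bromophenyl in place of 4-chlorophenyl on a saturated chain carbon bound to an oxygen on an aromatic ring. In words, 3-bromophenyl stands in place of 4-chlorophenyl on a saturated chain carbon bound to an oxygen on an aromatic ring.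

For the measured compounds named here, only one measured step bears on this, an at least 2.2-fold lower number from compound 1 to compound 2 (0.35 log units; beyond the scatter). That step replaced a (3-methoxyphenyl)carbonyl group with 4-chlorobenzyl, a different kind of change from the swap of one halogen-bearing benzyl group for another, so it offers only weak guidance here. Going by the values given here, no measured step covers a swap of this kind, so no shift in either direction can be argued for. The expected change in this assay is a 1.0-fold higher number from compound 2 to compound 3 (0.00 log units; within the scatter), which means no expected change beyond the scatter. For compound 3 the estimated value is 4500 nM, with an expected range from 1800 nM to 10000 nM.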

Compound 3, half-maximal inhibitory concentration: 1200 nM
For compound 3 the middle estimate is 3.8-fold (0.57 log units) above the measured one; the measured number lies below the stated range.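

In this assay, the outer ring on this saturated chain carbon proves to be a place where the number can move: 3-bromophenyl in place of 4-chlorophenyl gives a 3.7-fold lower number from compound 2 to compound 3 (0.57 log units; beyond the scatter). The two groups match in heavy-atom count and in hydrogen-bond donors and acceptors, so a swap that leaves those counts unchanged can still shift the result beyond the scatter, something compound 2 on its own could not show. With 3-bromobenzyl in place of (3-methoxyphenyl)carbonyl on the oxygen, the series also shows an at least 8.3-fold lower number from compound 1 to compound 3 (0.92 log units; beyond the scatter), and that size is only a bound because compound 1 rests on a limit of the assay, not on a number: the limit of > 10000 nM in this assay, at which 1 of the 3 values shown sits.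

On these data alone, what stays open is whether the halogen or its place on the ring matters here, since 3-bromophenyl differs from 4-chlorophenyl in both, and 3-chlorophenyl or 4-bromophenyl on the same chain carbon would pull those two apart. Also open, as far as these compounds go, is how far this position tolerates groups with no halogen at all, such as an amine or a methoxy group on the ring, or a longer chain in place of the single chain carbon.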